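The source may hold more compounds than are shown below. What is called first, only, known or untested is meant among the compounds shown, and "the series" means these compounds.

Three compounds share one core. Compound 1 `O=C(Nc1nc2ccc(Cl)cc2s1)c1cn(-c2ccccc2)nc1-c1ccccc1` gives in an ADME assay on HEK-293T cells (Homo sapiens) for cytotoxicity, read by MTT assay, with a stated time of 72 h (a higher number here means a weaker inhibitor, a lower number a stronger inhibitor), a value of 21300 nM; compound 2 `COc1ccc(-c2nn(-c3ccccc3)cc2C(=O)Nc2nc3ccccc3s2)cc1` gives in this assay a value of 18900 nM; compound 3 `COc1ccc(-c2nn(-c3ccccc3)cc2C(=O)Nc2nc3ccc(F)cc3s2)cc1` gives in this assay a value of 15400 nM. Compound 3 holds the lowest of the three numbers, yet compound 2 and compound 1 both lie within the scatter of it. Among the measured compounds shown here, the only single-place step measured, a 1.2-fold lower number from compound 2 to compound 3 (0.09 log units; within the scatter), stays within the scatter. Compound 4 `COc1ccc(-c2nn(-c3ccccc3)cc2C(=O)Nc2nc3ccc(Cl)cc3s2)cc1` differs from compound 3 by chloro in place of fluoro on an aromatic carbon. For the measured compounds named here, no measured pair isolates this exchange; compound 1 and compound 2 differ in two places, and their values lie within the scatter of each other. The expected step, a 1.0-fold lower number from compound 3 to compound 4 (0.01 log units; within the scatter), is therefore one within the scatter. Compound 4 is estimated at 15000 nM, between 8000 nM and 30000 nM.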

Compound 4, half-maximal inhibitory concentration: 12600 nM
Estimate against measurement, compound 4: 1.2-fold (0.08 log units) above; the measured number falls inside the stated range.
By their numbers in this assay, from the lowest: compounds 4, 3, 2 and 1 (each within the scatter of the next).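

Through this assay, the step from fluoro to chloro at this place on the benzothiazole gives a 1.2-fold lower number from compound 3 to compound 4 (0.09 log units; within the scatter) and so adds a second halogen exchange that leaves the number within the scatter. Chloro in place of hydrogen gives a 1.5-fold lower number from compound 2 to compound 4 (0.18 log units; within the scatter) and methoxy in place of hydrogen gives a 1.7-fold lower number from compound 1 to compound 4 (0.23 log units; within the scatter) as the widest step here, and neither leaves the scatter. Nothing shown offers any explanation for these steps. As far as these compounds go, whether an amine or a carboxylic acid at this place, or a longer chain in place of methoxy, would move the number beyond the scatter remains open.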